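This account rests on a few compounds, and the source may have more. Where it says the series, first, only, none or still open, it means among the compounds named here.

Values in a functional assay on NUGC-3 cells (Homo sapiens) for cytotoxicity, read by sulforhodamine B assay, with a stated time of 72 h; a higher number here means a weaker inhibitor of growth, a lower number a stronger inhibitor of growth:
compound 1 `O=C(Nc1ccccc1O)C1CCc2ccccc2N1C(=O)c1ccccc1Cl`: 36800 nM
compound 2 `O=C(Nc1ccccc1O)C1CCc2ccccc2N1C(=O)c1ccccc1`: 3780 nM
compound 3 `O=C(Nc1cc(C(F)(F)F)cc(C(F)(F)F)c1)C1CCc2ccccc2N1C(=O)c1ccccc1`: 1680 nM

Compound 1 differs from compound 2 by chloro in place of hydrogen on an aromatic carbon, and the result is a 9.7-fold higher number from compound 2 to compound 1 (0.99 log units; beyond the scatter). Compound 3 differs from compound 2 in its core; that difference is not broken down here. Compound 3 has the lowest number of the three.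

Compound 4 `O=C(Nc1cc(C(F)(F)F)cc(C(F)(F)F)c1)C1CCc2ccccc2N1C(=O)c1cccc(Cl)c1` is not yet measured. It differs from compound 3 by chloro in place of hydrogen on an aromatic carbon. This is the same kind of change as that from compound 2 to compound 1, not the same: there the chloro enters ortho to a large group, here meta to a large group, and the core is that of compound 3 rather than compound 2. In this assay, among the compounds with values here, the step is expected to be smaller than the earlier one, a 2.1-fold higher number from compound 3 to compound 4 (0.32 log units; beyond the scatter), because a 9.7-fold higher number from compound 2 to compound 1 (0.99 log units; beyond the scatter) is the only such step at hand and was made at a different place and on a different core. For compound 4 the expected value is 3500 nM, with a range from 1200 nM to 12000 nM.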

Compound 4, concentration for 50% growth inhibition: 560 nM
The estimate for compound 4 lay 6.3-fold (0.80 log units) above the measured number; measured number outside the range, below it.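

In this assay, chloro in place of hydrogen on the benzoyl ring gives a 3.0-fold lower number from compound 3 to compound 4 (0.48 log units; beyond the scatter). On these two cores the change does not carry over, and its direction reverses: the same change on two cores in this assay, a 9.7-fold higher number (0.99 log units; beyond the scatter) from compound 2 to compound 1 and a 3.0-fold lower number (0.48 log units; beyond the scatter) from compound 3 to compound 4, 29-fold (1.47 log units) apart, beyond the scatter of two such steps

Within the data shown here, this does not show that the core alone sets the outcome, since the chloro also stands at a different place in the two pairs, and the two differences cannot be separated with only one step on each core. The compounds shown leave open how a 3-chlorophenyl group behaves on the core of compound 2. They also leave open whether a fluoro, methoxy or amine group at that place on the core of compound 3 would follow chloro.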